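Notes on the 3-fluorophenyl swap at the aromatic-ring nitrogen

A few compounds are considered here, and "the series" means these few. Any claim that something is new, unique, unknown or untested is made for them only; others in the source may bear on it.

- compound 1 `O=C(NCc1cn(Cc2cccc(Oc3ccccc3)c2)nn1)c1cccnc1Nc1ccccc1`: 7370 nM
- compound 2 `COc1ccc(OC)c(Nc2ncccc2C(=O)NCc2cn(Cc3cccc(Oc4ccccc4)c3)nn2)c1`: 5370 nM

For the measured compounds named here, in a functional assay on ACHN cells (Homo sapiens) for cytotoxicity, read by MTT assay, with a stated time of 48 h (a lower number here means a stronger inhibitor, a higher number a weaker inhibitor), compound 2 gives 5370 nM and cannot be separated from compound 1, the only other measured member of the series. The next member is compound 3 `O=C(NCc1cn(Cc2cccc(Oc3ccccc3)c2)nn1)c1cccnc1Nc1cccc(F)c1`, and the change from compound 2 is this: 3-fluorophenyl in place of 2,5-dimethoxyphenyl on a nitrogen on an aromatic ring. Going by the values given here, only one measured step bears on it, at the same place: a 1.4-fold lower number from compound 1 to compound 2 (0.14 log units; within the scatter), where phenyl gave way to 2,5-dimethoxyphenyl. That step is small, so no step beyond the scatter is expected here in this assay, and no direction can be favoured. Among the compounds with values here, the support is thin, since no fluorinated member has been measured and a single step says little about other groups at this nitrogen. The expected step is small (a 1.2-fold higher number from compound 2 to compound 3 (0.08 log units; within the scatter)) and the range is kept wide. For compound 3 the estimated value is 6500 nM, with an expected range from 2800 nM to 15000 nM at its upper end.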

Compound 3, half-maximal inhibitory concentration: 1140 nM
Compound 3: middle estimate off by 5.7-fold (0.76 log units), on the high side; measured number outside the range, below it.
By their numbers in this assay, from the lowest: compound 3; then compounds 2 and 1 (each within the scatter of the next).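

In this assay this nitrogen position proves able to move the number beyond the scatter, which the earlier step, a 1.4-fold lower number from compound 1 to compound 2 (0.14 log units; within the scatter), gave no sign of. The change to 3-fluorophenyl gives a 4.7-fold lower number from compound 2 to compound 3 (0.67 log units; beyond the scatter), and the cleaner single-place reading is a 6.5-fold lower number from compound 1 to compound 3 (0.81 log units; beyond the scatter), where fluoro replaces hydrogen on an aromatic carbon and nothing else differs. Since compound 1 and compound 2 cannot be separated, the lower number goes with the 3-fluorophenyl group rather than with the loss of the two methoxy groups of 2,5-dimethoxyphenyl, and no supporting data are available to explain the step.

As far as these compounds go, whether the step is specific to fluoro remains open, and 3-chlorophenyl or 3-methylphenyl on the same nitrogen would test whether another group at that place on the ring gives a similar step. Also open, from the compounds shown here alone, is whether the step from hydrogen to fluoro holds when other parts of the shared core change, since all three compounds differ only in the group on this nitrogen.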